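The compounds below may be only part of what the source reports. "The series", "measured", "known", "first", "only" and "open" are said of these compounds alone.

Working notes on the series. In a functional assay on CCRF-CEM cells (Homo sapiens) (a higher number here means that more compound is tolerated, a lower number that less compound is tolerated), compound 2 `COC(=O)CCCCn1c(=O)c(C)cn([C@@H]2O[C@H](CO[Si](C)(C)C(C)(C)C)[C@@]3(OS(=O)(=O)C=C3N)[C@H]2O[Si](C)(C)C(C)(C)C)c1=O` gives 125000 nM, the higher of the two actual numbers, while compound 1 `Cc1cn([C@@H]2O[C@H](CO[Si](C)(C)C(C)(C)C)[C@@]3(OS(=O)(=O)C=C3N)[C@H]2O[Si](C)(C)C(C)(C)C)c(=O)n(CC2CC2)c1=O` gives 60400 nM. Compound 3 `CCCCOC(=O)CN(CCCn1c(=O)c(C)cn([C@@H]2O[C@H](CO[Si](C)(C)C(C)(C)C)[C@@]3(OS(=O)(=O)C=C3N)[C@H]2O[Si](C)(C)C(C)(C)C)c1=O)CC(=O)OCCCC` returns only a limit, > 250000 nM. This is the limit of > 250000 nM in this assay, at which 1 of the 3 values shown sits, so it gives a bound and no exact position.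

The step now in question leads to compound 4 `Cc1cn([C@@H]2O[C@H](CO[Si](C)(C)C(C)(C)C)[C@@]3(OS(=O)(=O)C=C3N)[C@H]2O[Si](C)(C)C(C)(C)C)c(=O)n(CCCN(CC(=O)O)CC(=O)O)c1=O`, which has not yet been measured: bis(carboxymethyl)amino in place of (methoxycarbonyl)methyl on a saturated chain carbon, three bonds along the chain from an aromatic nitrogen. In words, bis(carboxymethyl)amino replaces (methoxycarbonyl)methyl on a saturated chain carbon, three bonds along the chain from an aromatic nitrogen. Cut one bond further out, this reads 4-(methoxycarbonyl)butyl to 3-(bis(carboxymethyl)amino)propyl.

Among the measured compounds shown here, only one measured step is available, a 2.1-fold higher number from compound 1 to compound 2 (0.32 log units; beyond the scatter), which is modest and changes a different group. Compound 3 bears most closely on the change, since it carries the same chain with its two acids as butyl esters, but its limit fixes no step size. For the measured compounds named here, no measured step isolates free acids from esters, so the expectation is weak. A small upward move in this assay is expected, no larger than the measured step and possibly within the scatter.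

The expected step is a 1.4-fold higher number from compound 2 to compound 4 (0.13 log units; within the scatter). For compound 4 the estimated value is 170000 nM, with an expected range of 80000 nM to 250000 nM.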

Compound 4, half-maximal cytotoxic concentration: > 250000 nM
Compound 4 ended at the assay's limit (the forecaster's own chance of this, stated with the estimate: 45%); middle value at least 1.4-fold (0.16 log units) away from the limit.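

In this assay compound 4 returns only a limit, > 250000 nM, and this puts a second compound at that ceiling: the limit of > 250000 nM in this assay, at which 2 of the 4 values shown sit.

With bis(carboxymethyl)amino in place of (methoxycarbonyl)methyl, three bonds along the chain from an aromatic nitrogen, the change gives an at least 2.0-fold higher number from compound 2 to compound 4 (0.30 log units; that floor lies within the scatter), so the part of the step that can be read does not clear the usual scatter. Among the compounds shown here, the longer comparison with the cyclopropyl end of the set gives an at least 4.1-fold higher number from compound 1 to compound 4 (0.61 log units; beyond the scatter), which is the first measured step of this size at this position and shows that a chain ending in bis(carboxymethyl)amino is tolerated at least as far as the butyl ester form in compound 3, with both compounds resting at the same limit, so the step between them cannot be read.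

Going by these compounds, the true values of compound 3 and compound 4 stay unknown, and so does any difference between the esters and the free carboxylic acids. Also open, on these data alone, is what the same chain gives with a single carboxymethyl arm, with a plain tertiary amine bearing methyl groups, or with a longer chain between the aromatic nitrogen and the amine.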